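Compound 3: 2-bromophenyl on the amide-type nitrogen

A few compounds are considered here, and "the series" means these few. Any claim that something is new, unique, unknown or untested is made for them only; others in the source may bear on it.

In an ADME assay on Vero 76 cells (Chlorocebus sabaeus) for cytotoxicity, read by crystal violet staining, with a stated time of 96 h (a higher number here means that more compound is tolerated, a lower number that less compound is tolerated), compound 2 (`C=C(C)CNC(=S)Nc1cccc(C(F)(F)F)c1`) gives > 100000 nM, which is a limit of the assay and not a number. Compound 3 (`FC(F)(F)c1cccc(NC(=S)Nc2ccccc2Br)c1`) has 2-bromophenyl in place of 2-methylprop-2-en-1-yl on an amide-type nitrogen. Going by the values given here, one measured step bears on this change: an at least 10-fold higher number from compound 1 to compound 2 (1.02 log units; beyond the scatter). That step is large and beyond the scatter, and it has 2-methylprop-2-en-1-yl replacing 4-iodophenyl at the same place. Compound 1 (`FC(F)(F)c1cccc(NC(=S)Nc2ccc(I)cc2)c1`) carries that 4-iodophenyl. Compound 3 carries 2-bromophenyl where compound 1 has 4-iodophenyl, so a large step to a lower number in this assay is expected, with compound 1 at 9500 nM as the guide. The expected step is an at least 8.3-fold lower number from compound 2 to compound 3 (0.92 log units; beyond the scatter). For compound 3 the estimate is 12000 nM, with an expected range of 4000 nM to 40000 nM.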

Compound 3, half-maximal cytotoxic concentration: 50000 nM
Beside the measured number, compound 3's estimate is 4.2-fold (0.62 log units) below it; measured number outside the range, above it.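

With an aromatic ring kept on the amide-type nitrogen, replacing 4-iodophenyl with 2-bromophenyl still moves the reading in this assay, giving a 5.3-fold higher number from compound 1 to compound 3 (0.72 log units; beyond the scatter), so the group's identity matters here even when a ring is retained. Against 2-methylprop-2-en-1-yl, the change gives an at least 2.0-fold lower number from compound 2 to compound 3 (0.30 log units; that floor lies within the scatter), and the true size of that step stays unknown. Compound 2 remains a limit of the assay and not a number, which restricts what that step can show: the limit of > 100000 nM in this assay, at which 1 of the 3 values shown sits.

The names 4-iodophenyl and 2-bromophenyl differ in both the halogen and its numbered place, and the compounds shown do not separate these two changes. Also open, from the compounds shown here alone, is how 4-bromophenyl, unsubstituted phenyl or a longer chain ending in an amine would read on this nitrogen.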